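Trifluoromethyl removal from compound 1: expected cytotoxicity

The compounds below may be only part of what the source reports. "The series", "measured", "known", "first", "only" and "open" are said of these compounds alone.

Within the data shown here, compound 1 `O=C(NC(=S)NNc1ncnc2ccccc12)c1ccc(C(F)(F)F)cc1` holds the highest number of the two measured so far in a functional assay on GLC82 cells (Homo sapiens) for cytotoxicity, read by MTT assay, with a stated time of 72 h (on this read-out lower numbers stand for stronger inhibition and higher numbers for weaker inhibition), where compound 1 gives 12200 nM. Among the measured compounds shown here, its nearest neighbour is compound 2 `COc1cc2ncnc(NNC(=S)NC(=O)c3ccccc3Cl)c2cc1OC`; in this assay compound 2 gives 10000 nM, a reading that lies within the scatter of the one for compound 1, so the two cannot be told apart. Compound 3 `O=C(NC(=S)NNc1ncnc2ccccc12)c1ccccc1` is not yet measured. It differs from compound 1 by hydrogen in place of trifluoromethyl on an aromatic carbon. For the measured compounds named here, no step between measured compounds is available to calibrate this change, and the two measured readings span only a narrow band. The change is therefore expected to leave the number within the scatter, with no clear direction, so that a 1.0-fold lower number from compound 1 to compound 3 (0.01 log units; within the scatter). In this assay compound 3 is expected to give 12000 nM, with a range estimated from 5000 nM to 28000 nM.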

Compound 3, half-maximal inhibitory concentration: 8370 nM
Compound 3: the middle estimate sits 1.4-fold (0.16 log units) above what was measured, within the range that was stated.
By their numbers in this assay, from the lowest: compounds 3, 2 and 1 (each within the scatter of the next).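

In this assay, among these compounds, the first readable step at this position gives a 1.5-fold lower number from compound 1 to compound 3 (0.16 log units; within the scatter) as trifluoromethyl gives way to hydrogen. On the core of compound 1, the four heavy atoms of trifluoromethyl can therefore be removed from this site, para to a large group, with no change that can be told from the scatter. The data on hand offer nothing that bears on why the reading holds.

From the compounds shown here alone, whether any group on this aromatic carbon can move the number beyond the scatter remains open, and an amine or a carboxylic acid there would be informative. Also open, going by these compounds, is whether the same exchange would behave alike on the core of compound 2, since a single step cannot show this.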